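The source may report more compounds than this note shows. Statements on the series, on what has been measured and on what is new or still open speak of the compounds shown alone.

Compound 1, `COc1ccc([C@H]2C[C@H](C(=O)O)C2)cc1-c1ccc(C(F)(F)F)cc1[C@@H]1CC[C@H]2[C@@H](c3cc(C(F)(F)F)cc(C(F)(F)F)c3)OC(=O)N12`: 4000 nM
Compound 2, `COc1ncc(-c2ccc(C(=O)O)cc2C)cc1-c1ncc(C(F)(F)F)cc1[C@@H]1CC[C@H]2[C@@H](c3cc(C(F)(F)F)cc(C(F)(F)F)c3)OC(=O)N12`: 7000 nM

Both numbers come from an ADME assay on isolated protein for inhibition of Voltage-dependent L-type calcium channel subunit alpha-1C (Homo sapiens); a lower number here means a stronger inhibitor, a higher number a weaker inhibitor. Compound 1 gives the lower of the two, yet its gap to compound 2 falls within the usual scatter, so neither can be called the stronger inhibitor. Compound 3, `COc1ccc(CCC(=O)O)cc1-c1ccc(C(F)(F)F)cc1[C@@H]1CC[C@H]2[C@@H](c3cc(C(F)(F)F)cc(C(F)(F)F)c3)OC(=O)N12`, is not yet measured. It differs from compound 1 in one place: 2-carboxyethyl in place of 3-carboxycyclobutyl on an aromatic carbon. With the shared core unchanged and only the acid-bearing arm altered, the step from compound 1 to compound 3 in this assay is expected to be small, most likely within the scatter, with a slight lean toward a higher number. Compound 3 is therefore estimated at 5500 nM, between 2000 nM and 15000 nM.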

Compound 3, half-maximal inhibitory concentration: 7000 nM
The estimate for compound 3 lay 1.3-fold (0.10 log units) below the measured number; low and high end bracket the measured number.
By their numbers in this assay, from the lowest: compounds 1, 2 and 3 (each within the scatter of the next).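

In this assay, replacing 3-carboxycyclobutyl with 2-carboxyethyl on this aromatic carbon gives a 1.8-fold higher number from compound 1 to compound 3 (0.24 log units; within the scatter). The four-membered ring and its two defined stereocentres can therefore give way to an open chain bearing the same carboxylic acid without the number moving beyond the scatter. Of the compounds shown, only this pair isolates a change at this position.

Going by these compounds, whether this aromatic carbon needs a carboxylic acid at all remains open, as does the effect of an amine or a longer chain ending in the acid. No measurement offers an explanation for this result.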